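This account rests on a few compounds, and the source may have more. Where it says the series, first, only, none or still open, it means among the compounds named here.

Measured so far in an ADME assay on MT4 cells (Homo sapiens) for cytotoxicity, read by MTT assay, with a stated time of 96 h; on this read-out lower numbers stand for higher toxicity in this test and higher numbers for lower toxicity in this test:
Compound 1 `Cc1cccc(C2CC(c3ccc(Oc4ccccc4)cc3)=NN2c2ccc(S(N)(=O)=O)cc2)c1` gives 35000 nM.
Compound 2 `NS(=O)(=O)c1ccc(N2N=C(c3ccc(OCc4ccccc4)cc3)CC2c2ccccc2)cc1` gives only a limit, > 100000 nM.
Compound 3 `NS(=O)(=O)c1ccc(N2N=C(c3ccc(OCc4ccccc4)cc3)CC2c2ccc(F)cc2)cc1` likewise gives only a limit, > 100000 nM.

Within the data shown here, compound 1 thus stands as the only value reported as a number; the other two sit at the limit of > 100000 nM in this assay, at which 2 of the 3 values shown sit. Among the measured compounds shown here, the single step between measured compounds that differ in one place, a step that the two limits leave unreadable from compound 2 to compound 3, therefore has no readable size.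

Compound 4 `NS(=O)(=O)c1ccc(N2N=C(c3ccc(Oc4ccccc4)cc3)CC2c2ccccc2Cl)cc1` differs from compound 1 by 2-chlorophenyl in place of 3-methylphenyl on a saturated ring carbon. For the measured compounds named here, no measured step covers this kind of change, so the data give no direction to expect beyond the scatter. Compound 4 is therefore expected to give about 50000 nM, in the range 20000 nM to 100000 nM. The expected step of a 1.4-fold higher number from compound 1 to compound 4 (0.15 log units; within the scatter) is small, and a limit rather than a number is a real possibility.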

Compound 4, half-maximal cytotoxic concentration: 40000 nM
Beside the measured number, compound 4's estimate is 1.3-fold (0.10 log units) above it; low and high end bracket the measured number.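

In this assay, putting 2-chlorophenyl in place of 3-methylphenyl on the saturated ring carbon gives a 1.1-fold higher number from compound 1 to compound 4 (0.06 log units; within the scatter). Among these compounds, this is the first readable step at this position, and it does not separate the two compounds. Compound 4 is reported as a number, as compound 1 is, while the other compounds stay at a limit: the limit of > 100000 nM in this assay, at which 2 of the 4 values shown sit.

This one swap changes both the atom on the phenyl ring and its place there, so the two changes cannot be told apart. From the compounds shown here alone, whether an amine or a carboxylic acid on this phenyl ring would move the number stays open.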